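The compounds below may be only part of what the source reports. "The series", "measured", "known", "first", "only" and "open" are said of these compounds alone.

Working notes on the series. For the measured compounds named here, in a physicochemical assay for solubility, in simulated intestinal fluid, measured as thermodynamic solubility, at pH 6.8 (on this read-out lower numbers stand for lower solubility and higher numbers for higher solubility), compound 1 (`CCC(CC)N1CCN(c2nc3c(c(Nc4ccc(C(F)(F)F)cc4)n2)CCN(c2ncccc2C(F)(F)F)CC3)CC1`) gives 109 ug/mL, while compound 2 (`FC(F)(F)c1ccc(Nc2nc(N3CCN(C4CCC4)CC3)nc3c2CCN(c2ncccc2C(F)(F)F)CC3)cc1`) gives 2 ug/mL, the lower of the two numbers so far. Going by the values given here, the only measured step is large and beyond the scatter: a 55-fold lower number from compound 1 to compound 2 (1.74 log units; beyond the scatter), with cyclobutyl in place of pentan-3-yl on an amine nitrogen in a ring. Compound 3 (`CN1CCCCC1CNc1nc2c(c(Nc3ccc(C(F)(F)F)cc3)n1)CCN(c1ncccc1C(F)(F)F)CC2`) has ((1-methylpiperidin-2-yl)methyl)amino in place of 4-cyclobutylpiperazin-1-yl on an aromatic carbon. Among the compounds with values here, no measured step covers this replacement of the whole group, so the evidence is indirect. Compound 2 stands at the low end, and a 55-fold lower number from compound 1 to compound 2 (1.74 log units; beyond the scatter) shows how far this assay can move within this small set, so a moderate to large rise is expected, with wide uncertainty. The expected step is a 10-fold higher number from compound 2 to compound 3 (1.00 log units; beyond the scatter). The estimated value for compound 3 is 20 ug/mL, with an expected range of 4 ug/mL to 100 ug/mL.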

Compound 3, solubility: 254 ug/mL
Beside the measured number, compound 3's estimate is 13-fold (1.10 log units) below it; measured number outside the range, above it.
By their numbers in this assay, from the lowest: compound 2; then compound 1; then compound 3.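

The position on the aromatic carbon para to a fused ring can move this read-out further than the earlier change on the piperazine nitrogen did: in this assay, ((1-methylpiperidin-2-yl)methyl)amino in place of 4-cyclobutylpiperazin-1-yl gives a 130-fold higher number from compound 2 to compound 3 (2.10 log units; beyond the scatter) for this step. Against the 4-(pentan-3-yl)piperazin-1-yl group, the same entering group gives a 2.3-fold higher number from compound 1 to compound 3 (0.37 log units; beyond the scatter) as a smaller step, so compound 3 holds the highest number of the three, and the size of its gain depends on which piperazine it is compared with. Nothing measured here accounts for either step.

As far as these compounds go, this change alters the ring, the link to the core and the hydrogen-bond donor count together, so the share of each remains open. From the compounds shown here alone, how a morpholine, or a simple dimethylamino group, would read at this aromatic carbon also remains open.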